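A Bromo for Methoxy Swap on the Shared Core

The compounds below may be only part of what the source reports. "The series", "measured", "known", "first", "only" and "open" are said of these compounds alone.

Measured so far in a toxicity assay on the whole organism with Rattus norvegicus as the target, at a dose of 100 mg/kg by the oral route; on this read-out higher numbers stand for a stronger effect at the one dose given and lower numbers for a weaker effect:
- compound 1, `COc1ccc(OCC2=NCCO2)cc1`, gives 5%
- compound 2, `Brc1ccccc1OCC1=NCCO1`, gives 10%
- compound 3, `Cc1cccc(OCC2=NCCO2)c1`, gives 15%

All three compounds share one core and differ only in what sits on the aromatic ring. In this assay compound 1 gives the smallest of the three figures, but compound 2 lies within the usual scatter of it and so does compound 3, so no ordering among them can be read from these numbers. Among the measured compounds shown here, no step between measured compounds that differ in a single place is available, and nothing is known about how any of them binds.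

The compound still to be measured is compound 4, `Brc1ccc(OCC2=NCCO2)cc1`. Set against compound 1 the change is bromo in place of methoxy on an aromatic carbon. Because compound 1 gives 5% and compound 2, which also carries a bromo group, gives 10%, the expected step of a number 5 percentage points higher from compound 1 to compound 4 (within the scatter) is none beyond the scatter, in either direction. On that basis compound 4 is expected to give about 10% in this assay, within a range from 0% to 30%.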

Compound 4, a percentage reported as activity, at one dose (the size of the read-out at that dose, not a potency): 5%
Compound 4: the middle estimate sits 5 percentage points above what was measured; the range from low to high includes it.
By their numbers in this assay, from the lowest: compounds 1, 4, 2 and 3 (each within the scatter of the next).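

In this assay, among the compounds shown here, the replacement of methoxy by bromo on an aromatic carbon, para to a group of 7 heavy atoms, gives the first comparison of compounds that differ in one place, and it reads no change at the digits printed from compound 1 to compound 4 (within the scatter) for this change. The earlier compounds shown here could not show this, as each of them differs from the others in more than one respect: here, methoxy with its 2 heavy atoms and 1 hydrogen-bond acceptor gives way to bromo with 1 heavy atom and 0 hydrogen-bond acceptors, and the read-out at the one dose given shows no step beyond the scatter. No measured information bears on the reason for this result.

Going by these compounds, whether an amine, a carboxylic acid or a longer alkoxy chain at this same place would also stay within the scatter of compound 1 remains open. Also open, on these data alone, is whether bromo and methoxy would read alike at another place on the aromatic ring, or at a dose other than the one given.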